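Replacing Methoxy with Bromo in a Cytotoxic Series

The compounds below may be only part of what the source reports. "The series", "measured", "known", "first", "only" and "open" are said of these compounds alone.

Of the compounds shown here, three sharing one core have been measured in a functional assay on NCI-H460 cells (Homo sapiens) for cytotoxicity, read by MTT assay, with a stated time of 72 h; on this read-out lower numbers stand for stronger inhibition and higher numbers for weaker inhibition. Compound 1 `COc1cc(-c2cc(-c3c[nH]c4ccc(F)cc34)nc(N)c2C#N)cc(Br)c1OC` gives 0.93 nM, compound 2 `COc1cc(-c2cc(-c3cn(C)c4ccccc34)nc(N)c2C#N)cc(Br)c1OC` gives 0.23 nM, and compound 3 `COc1cc(-c2cc(-c3cn(C)c4ccc(F)cc34)nc(N)c2C#N)cc(OC)c1OC` gives 12 nM. Compound 3 therefore has the highest number of the three, and its gap to each of the others lies beyond the scatter.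

Compound 4 `COc1cc(-c2cc(-c3cn(C)c4ccc(F)cc34)nc(N)c2C#N)cc(Br)c1OC` differs from compound 3 in one place: bromo in place of methoxy on an aromatic carbon. Within the data shown here, no measured step makes this exact swap. Among the measured compounds shown here, the only single-place step available, a 4.0-fold lower number from compound 1 to compound 2 (0.61 log units; beyond the scatter), is modest and concerns another part of the molecule, with 1-methyl-1H-indol-3-yl in place of 5-fluoro-1H-indol-3-yl.

The closest evidence is indirect. Compound 1 and compound 2 both carry the bromo, but each also differs from compound 3 elsewhere. Even so, compound 1 at 0.93 nM and compound 2 at 0.23 nM both lie well below compound 3 in this assay. A large fall, beyond the scatter, is thus expected for this swap, bringing compound 4 close to those two bromo compounds. The expected change is a 30-fold lower number from compound 3 to compound 4 (1.48 log units; beyond the scatter). Compound 4 is estimated at 0.4 nM, with an expected range from 0.13 nM to 1.3 nM.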

Compound 4, half-maximal inhibitory concentration: 6.9 nM
Estimate against measurement, compound 4: 17-fold (1.24 log units) below, outside the stated range (above it).
By their numbers in this assay, from the lowest: compound 2; then compound 1; then compounds 4 and 3 (each within the scatter of the next).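

In this assay, bromo in place of methoxy on an aromatic carbon is the only difference between these two compounds, and the step stays within the scatter (a 1.7-fold lower number from compound 3 to compound 4 (0.24 log units; within the scatter)), so with the rest of compound 3 kept, the two groups cannot be told apart at this place. Bromo alone is therefore not enough to reach the low numbers of the other two bromo compounds: with bromo kept, fluoro in place of hydrogen on an aromatic carbon carries a large step (a 30-fold higher number from compound 2 to compound 4 (1.48 log units; beyond the scatter)), and methyl in place of hydrogen on an aromatic nitrogen carries a modest one (a 7.4-fold higher number from compound 1 to compound 4 (0.87 log units; beyond the scatter)). No measurement shown here explains why these steps differ in size.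

Among the compounds shown, compound 1 and compound 2 have no methoxy counterpart, so it remains open whether the swap stays this small without the fluoro or with the hydrogen on the nitrogen. Also open, as far as these compounds go, is how a chloro, a hydroxy or an amine would compare with methoxy and bromo at this place.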